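The compounds below may be only part of what the source reports. "The series", "measured", "known", "first", "only" and "open" are said of these compounds alone.

Compound 1 `CCCCc1ccc(CNS(=O)(=O)c2ccc(C)cc2)c(=O)n1Cc1ccc(-c2ccccc2-c2nn[nH]n2)cc1` gives 9 nM in a functional assay (aorta) for antagonist activity, with Oryctolagus cuniculus as the target; on this read-out higher numbers stand for weaker inhibition and lower numbers for stronger inhibition. Compound 2 `CCCCc1ccc(CNS(=O)(=O)c2ccccc2)c(=O)n1Cc1ccc(-c2ccccc2-c2nn[nH]n2)cc1` gives 7 nM in this assay, and compound 3 `CCCCc1ccc(CNS(C)(=O)=O)c(=O)n1Cc1ccc(-c2ccccc2-c2nn[nH]n2)cc1` gives 2 nM, the lowest of the three numbers, beyond the scatter from both others. Compound 4 `CCCCc1ccc(CN(C)S(=O)(=O)c2ccc(C)cc2)c(=O)n1Cc1ccc(-c2ccccc2-c2nn[nH]n2)cc1` carries methyl((4-methylphenyl)sulfonyl)amino in place of methanesulfonamido on a saturated chain carbon bound to an aromatic carbon. For the measured compounds named here, the step of a 4.5-fold lower number from compound 1 to compound 3 (0.65 log units; beyond the scatter) is the reverse of the sulfonyl part of this change, and a 3.5-fold lower number from compound 2 to compound 3 (0.54 log units; beyond the scatter) went the same way; the methyl that replaces the hydrogen on the nitrogen has no measured counterpart here. Restoring the 4-methylphenyl on the sulfonyl sulfur is therefore expected to raise the number, by about a 6.0-fold higher number from compound 3 to compound 4 (0.78 log units; beyond the scatter) in this assay. The estimate for compound 4 is 12 nM, with a range from 4 nM to 40 nM.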

Compound 4, half-maximal inhibitory concentration: 8 nM
Estimate against measurement, compound 4: 1.5-fold (0.18 log units) above; low and high end bracket the measured number.
By their numbers in this assay, from the lowest: compound 3; then compounds 2, 4 and 1 (each within the scatter of the next).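

Putting methyl in place of hydrogen on the sulfonamide nitrogen gives a 1.1-fold lower number from compound 1 to compound 4 (0.05 log units; within the scatter) in this assay and so, within the scatter, changes nothing. Compound 4 also gives a 1.1-fold higher number from compound 2 to compound 4 (0.06 log units; within the scatter) when set against the unmethylated phenyl sulfonamide, whereas the full exchange gives a 4.0-fold higher number from compound 3 to compound 4 (0.60 log units; beyond the scatter) and thus remains beyond the scatter, so the sulfonamide hydrogen is not needed to keep these low numbers. No supporting evidence is available to explain this result.

The compounds shown leave open how nitrogen methylation behaves with the methanesulfonyl group of compound 3. As far as these compounds go, whether a longer chain such as propyl on that nitrogen fits equally well also remains open.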